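A few compounds are considered here, and "the series" means these few. Any claim that something is new, unique, unknown or untested is made for them only; others in the source may bear on it.

Compounds with measured values:
Compound 1, `COc1cc2cc(Oc3ccc(NC(=O)Nc4ccc(C(F)(F)F)cc4)cc3)c(C)nc2cc1OC`, 44.6% in a functional assay on HT-29 cells (Homo sapiens) for inhibition, read by sulforhodamine B assay, with a stated time of 48 h, tested at 10 uM; a higher number here means a weaker effect of the compound at the concentration tested, a lower number a stronger effect.
Compound 2, `COc1cc2cc(Oc3ccc(NC(=O)Nc4cccc(C(F)(F)F)c4)cc3)c(C)nc2cc1OC`, 6.56%.

Compound 2 stands lowest of the two numbers shown; the single measured step, a number 38 percentage points lower from compound 1 to compound 2 (beyond the scatter), is large. Compound 3, `COc1cc2cc(Oc3ccc(NC(=O)Nc4ccc(Cl)c(C(F)(F)F)c4)cc3)c(C)nc2cc1OC`, differs from compound 2 by chloro in place of hydrogen on an aromatic carbon. Among the measured compounds shown here, no measured step involves a chloro group, so the earlier step gives no direct guide here. Compound 2 already sits near the bottom of the scale, which leaves little room for a further drop. The step expected is a number 3.4 percentage points higher from compound 2 to compound 3 (within the scatter), that is, nothing beyond the scatter. Compound 3 is therefore estimated at 10%, within a range from 2% to 30%.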

Compound 3, a percentage reported as activity, at one concentration (the size of the read-out at that concentration, not a potency): -24.9%
The estimate for compound 3 lay 34.9 percentage points above the measured number; measured number below the stated range.
By their numbers in this assay, from the lowest: compound 3; then compound 2; then compound 1.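

The aromatic carbon para to a large group, ortho to the trifluoromethyl group, proved open to change: chloro in place of hydrogen gave a number 31.5 percentage points lower from compound 2 to compound 3 (beyond the scatter). Compound 2 was therefore not at the end of the scale, and compound 3 gives a negative number, -24.9%. The 4-chloro-3-(trifluoromethyl)phenyl group also gave a number 69.5 percentage points lower from compound 1 to compound 3 (beyond the scatter), and no evidence on hand accounts for either step.

As far as these compounds go, whether a bromo or methoxy group at this carbon would match chloro remains open. So does whether chloro would give a similar step without the neighbouring trifluoromethyl group.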